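Removing a Trifluoromethyl from a Long-Lived Compound

The source may hold more compounds than are shown below. What is called first, only, known or untested is meant among the compounds shown, and "the series" means these compounds.

compound 1 `O=C(NCc1ccc(C(F)(F)F)cc1)N1C(=O)c2ccccc2S1(=O)=O`: > 166 h
compound 2 `O=C(NCc1ccccc1C(F)(F)F)N1C(=O)c2ccccc2S1(=O)=O`: > 166 h

Of the compounds shown here, two have been measured in a physicochemical assay for pharmacokinetics; on this read-out higher numbers stand for a longer-lived compound and lower numbers for a shorter-lived compound. Compound 1 is `O=C(NCc1ccc(C(F)(F)F)cc1)N1C(=O)c2ccccc2S1(=O)=O`. In this assay compound 1 reaches the limit of the assay, reported as > 166 h. Compound 2 is `O=C(NCc1ccccc1C(F)(F)F)N1C(=O)c2ccccc2S1(=O)=O`. In this assay compound 2 likewise reaches the limit, reported as > 166 h. Compound 2 therefore stands at the limit of > 166 h in this assay, at which 2 of the 2 values shown sit, and nothing in the numbers separates it from compound 1, since both values are limits and not numbers.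

The untested compound 3 is `O=C(NCc1ccccc1)N1C(=O)c2ccccc2S1(=O)=O`. It differs from compound 2 by hydrogen in place of trifluoromethyl on an aromatic carbon. Among the compounds with values here, no step between measured compounds is available, so the size of this step has to be guessed from what the two measured compounds show. Because both sit at the limit of > 166 h in this assay, at which 2 of the 2 values shown sit, the expectation is that compound 3 remains long-lived, with an expected step that the limit leaves unreadable from compound 2 to compound 3 that lies within the scatter or again ends at the limit. Compound 3 is expected to give 170 h, in a range from 60 h to 400 h.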

Compound 3, half-life: > 166 h
Compound 3 ended at the assay's limit (the forecaster's own chance of this, stated with the estimate: 65%); the middle value is on the limit's open side.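

In this assay compound 3 gives > 166 h as a limit and not a number. Within the data shown here, compounds 1 and 2 also stand at limits, so no step from either of them to compound 3 can be read. The compounds shown leave open how long each one actually lasts and whether trifluoromethyl makes any difference to that.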